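A few compounds are considered here, and "the series" means these few. Any claim that something is new, unique, unknown or untested is made for them only; others in the source may bear on it.

Of the compounds shown here, two built on a shared core have been tested so far. For the measured compounds named here, in a functional assay on DU-145 cells (Homo sapiens) for antiproliferative activity, read by MTT assay (a higher number here means a weaker inhibitor, a lower number a stronger inhibitor), compound 2 `Cc1ccc2[nH]c(-c3c(-c4ccc(F)cc4)nc4sc(C)nn34)nc2c1` gives 19900 nM, the only actual number available. Compound 1 `Cc1nn2c(-c3nc4cc(Cl)c(F)cc4[nH]3)c(-c3ccc(F)cc3)nc2s1` reaches only a limit of the assay, > 30000 nM, which is not a number.

Compound 3 `Cc1nn2c(-c3nc4cc(Cl)ccc4[nH]3)c(-c3ccc(F)cc3)nc2s1` has not yet been measured. It differs from compound 2 by a single swap, chloro in place of methyl on an aromatic carbon, on a six-membered aromatic ring of carbon only that is part of a fused system of two rings.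

Going by the values given here, no measured pair shows what this swap does in this assay, so no change beyond the usual scatter is expected. Starting from compound 2 at 19900 nM, the expected step of a 1.1-fold higher number from compound 2 to compound 3 (0.04 log units; within the scatter) is small. Compound 3 is estimated at 22000 nM, with an expected range of 9000 nM to 30000 nM.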

Compound 3, half-maximal inhibitory concentration: 14400 nM
Compound 3: middle estimate off by 1.5-fold (0.18 log units), on the high side; the measured number falls inside the stated range.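

In this assay, chloro in place of methyl on this carbon of the fused ring gives a 1.4-fold lower number from compound 2 to compound 3 (0.14 log units; within the scatter), so this pair does not separate the two groups. Hydrogen in place of fluoro on an aromatic carbon of the same ring gives an at least 2.0-fold lower number from compound 1 to compound 3 (0.31 log units; beyond the scatter), the first step in this set that is beyond the scatter, and it suggests that removing the fluoro matters more here than exchanging methyl for chloro. From the compounds shown here alone, the true size of that step stays unknown because compound 1 reaches only a limit of the assay, not a number: the limit of > 30000 nM in this assay, at which 1 of the 3 values shown sits.

Going by these compounds, what an amine or a carboxylic acid on this carbon would do remains open. So does how much the numbers would move with a change elsewhere on the shared core.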